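Sulfonyl aryl change from compound 3 to compound 4

The source may hold more compounds than are shown below. What is called first, only, known or untested is meant among the compounds shown, and "the series" means these compounds.

Measured in a functional assay on K562 cells (Homo sapiens) for inhibition, read by trypan blue exclusion, with a stated time of 72 h (on this read-out higher numbers stand for weaker inhibition and lower numbers for stronger inhibition), with these results:
- compound 1 `Cn1c(=O)c(S(=O)(=O)c2ccc(Cl)cc2Cl)cc2cnc(Nc3ccc4[nH]ccc4c3)nc21` gives 1000 nM
- compound 2 `Cn1c(=O)c(S(=O)(=O)Cc2ccc(F)cc2)cc2cnc(Nc3ccc4[nH]ccc4c3)nc21` gives 30000 nM
- compound 3 `Cn1c(=O)c(S(=O)(=O)c2ccc(Cl)cc2)cc2cnc(Nc3ccc4[nH]ccc4c3)nc21` gives 100 nM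

Compound 3 holds the lowest of the three numbers, and its gaps to both others lie beyond the scatter. Compound 4 `Cn1c(=O)c(S(=O)(=O)c2ccc(F)cc2[N+](=O)[O-])cc2cnc(Nc3ccc4[nH]ccc4c3)nc21` departs from it by 4-fluoro-2-nitrophenyl in place of 4-chlorophenyl on a sulfonyl sulfur.

Among the measured compounds shown here, two measured steps bear on this change. The closer one is a 10-fold lower number from compound 1 to compound 3 (1.00 log units; beyond the scatter) (hydrogen in place of chloro on an aromatic carbon), and compound 4 resembles compound 1 in carrying two substituents on the phenyl. The other is a 300-fold lower number from compound 2 to compound 3 (2.48 log units; beyond the scatter) (4-chlorophenyl in place of 4-fluorobenzyl on a sulfonyl sulfur); it concerns a benzyl group that compound 4 lacks, so it counts for little. For the measured compounds named here, no measured compound carries a nitro group.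

In this assay the expected result is a 5.0-fold higher number from compound 3 to compound 4 (0.70 log units; beyond the scatter) toward weaker inhibition, on thin evidence. Compound 4 is estimated at 500 nM with an expected range of 120 nM to 2500 nM for now.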

Compound 4, half-maximal inhibitory concentration: 900 nM
Beside the measured number, compound 4's estimate is 1.8-fold (0.26 log units) below it; the measured number falls inside the stated range.
By their numbers in this assay, from the lowest: compound 3; then compounds 4 and 1 (each within the scatter of the next); then compound 2.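

In this assay the 4-fluoro-2-nitrophenyl group on the sulfonyl sulfur costs activity against the 4-chlorophenyl group (a 9.0-fold higher number from compound 3 to compound 4 (0.95 log units; beyond the scatter)), and it lands level with the 2,4-dichlorophenyl group (a 1.1-fold lower number from compound 1 to compound 4 (0.05 log units; within the scatter)), so among these three aryl sulfones both phenyls with two substituents sit on the weaker side of compound 3. Even so, the new aryl group remains well ahead of 4-fluorobenzyl (a 33-fold lower number from compound 2 to compound 4 (1.52 log units; beyond the scatter)), so the large penalty seen for the benzyl group in compound 2 is not approached by this substitution. Nothing measured on these compounds accounts for these steps.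

Compound 4 differs from compound 3 by both fluoro for chloro and an added nitro group, and the share of each stays unresolved. From the compounds shown here alone, whether an amine or a nitrile in place of the nitro group would give a similar number also remains open.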